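The compounds below may be only part of what the source reports. "The series", "measured", "known", "first", "only" and "open" are said of these compounds alone.

Measured compounds and their results:

compound 1 `CC1CCN(Cc2ccc3nc(NC(=O)N/N=C/c4cn(Cc5cccc(Cl)c5)c5ccccc45)sc3c2)CC1` — 2110 nM
compound 2 `CCN(CC)Cc1ccc2nc(NC(=O)N/N=C/c3cn(Cc4cccc(Cl)c4)c4ccccc34)sc2c1` — 2050 nM
compound 3 `CN(C)Cc1ccc2nc(NC(=O)N/N=C/c3cn(Cc4cccc(Cl)c4)c4ccccc34)sc2c1` — 1140 nM

All three share one core and were tested in a functional assay on MDA-MB-231 cells (Homo sapiens) for cytotoxicity, read by MTT assay, with a stated time of 72 h; on this read-out higher numbers stand for weaker inhibition and lower numbers for stronger inhibition. Compound 2 holds the second highest of the three numbers: compound 1 lies nearest to it and compound 3 furthest, and both gaps are within the scatter. The measured steps all change the amine on a saturated chain carbon bound to an aromatic carbon: a 1.0-fold lower number from compound 1 to compound 2 (0.01 log units; within the scatter), a 1.8-fold lower number from compound 2 to compound 3 (0.25 log units; within the scatter) and a 1.9-fold lower number from compound 1 to compound 3 (0.27 log units; within the scatter). Among the measured compounds shown here, every one of them stays within the scatter, so this series so far sits in a narrow band.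

Compound 4 `CCN(CC)Cc1ccc2nc(NC(=O)N/N=C/c3cn(Cc4ccccc4Cl)c4ccccc34)sc2c1` differs from compound 2 in another part of the molecule: 2-chlorophenyl in place of 3-chlorophenyl on a saturated chain carbon bound to an aromatic nitrogen. For the measured compounds named here, no measured step touches the chlorophenyl group, so none bears directly on this change; the only guidance is the narrow band seen so far. Relative to compound 2, the step expected for compound 4 is a 1.0-fold lower number from compound 2 to compound 4 (0.01 log units; within the scatter), in no particular direction and not beyond the scatter. Compound 4 is therefore estimated at 2000 nM, with a range from 900 nM to 4500 nM.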

Compound 4, half-maximal inhibitory concentration: 900 nM
The estimate for compound 4 lay 2.2-fold (0.35 log units) above the measured number, and the stated range covers the measured number.
By their numbers in this assay, from the lowest: compounds 4, 3, 2 and 1 (each within the scatter of the next, the first and the last beyond it).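

Changing 3-chlorophenyl to 2-chlorophenyl on a saturated chain carbon bound to an aromatic nitrogen gives a 2.3-fold lower number from compound 2 to compound 4 (0.36 log units; beyond the scatter) in this assay. This is the only step shown that lies beyond the scatter, modest as it is, and it falls outside the amine changes that make up the earlier steps: the two compounds have the same atoms, so where the chlorine sits on this ring is enough to shift the number. The data shown offer no measurement that explains this shift.

On these data alone, whether the same change would shift the number similarly with dimethylamino or 4-methylpiperidin-1-yl in place of diethylamino remains open, as this pair carries diethylamino only. Also open, as far as these compounds go, is how 4-chlorophenyl, 2-fluorophenyl or 2-methoxyphenyl would compare at this position.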